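From diethylamino to pyrrolidin-1-yl on a carbonyl carbon

The compounds below may be only part of what the source reports. "The series", "measured", "known", "first", "only" and "open" are said of these compounds alone.

- Compound 1 `COC/C1=C/C[C@](C)(CCC=C(C)C)/C=C/[C@@H](OC(=O)C=C(C)C)[C@](C)(O)/C=C/C1=O`: 3070 nM
- Compound 2 `CC(C)=CCC[C@]1(C)/C=C/[C@@H](OC(=O)C=C(C)C)[C@](C)(O)/C=C/C(=O)/C(C[Si](C)(C)C(C)(C)C)=C\C1`: 2770 nM
- Compound 3 `CCN(CC)C(=O)/C1=C/C[C@](C)(CCC=C(C)C)/C=C/[C@@H](OC(=O)C=C(C)C)[C@](C)(O)/C=C/C1=O`: 9080 nM

In a functional assay on HL-60 cells (Homo sapiens) for antiproliferative activity, read by MTT assay, with a stated time of 48 h (a lower number here means a stronger inhibitor, a higher number a weaker inhibitor), compound 3 gives the highest number of the three, 9080 nM, and is the weakest inhibitor measured so far. Compound 4 `CC(C)=CCC[C@]1(C)/C=C/[C@@H](OC(=O)C=C(C)C)[C@](C)(O)/C=C/C(=O)/C(C(=O)N2CCCC2)=C\C1` keeps the shared core and changes only pyrrolidin-1-yl in place of diethylamino on a carbonyl carbon.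

For the measured compounds named here, no measured step makes this exact change, since compound 3 is the only measured compound carrying diethylamino. The nearest evidence comes from replacing the whole group on the double-bonded ring carbon. Those steps are modest: a 3.0-fold higher number from compound 1 to compound 3 (0.47 log units; beyond the scatter) and a 3.3-fold higher number from compound 2 to compound 3 (0.52 log units; beyond the scatter). The exchange of the other two groups, a 1.1-fold lower number from compound 1 to compound 2 (0.04 log units; within the scatter), stays within the scatter. The change in compound 4 is smaller than the replacements behind those modest steps, so no step beyond the scatter is expected in this assay.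

The expected step is a 1.1-fold lower number from compound 3 to compound 4 (0.05 log units; within the scatter). The estimated value for compound 4 is 8000 nM, with an expected range of 3500 nM to 18000 nM.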

Compound 4, half-maximal inhibitory concentration: 12300 nM
The estimate for compound 4 lay 1.5-fold (0.19 log units) below the measured number; the range from low to high includes it.
By their numbers in this assay, from the lowest: compounds 2 and 1 (each within the scatter of the next); then compounds 3 and 4 (each within the scatter of the next).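

Tying the amine into one five-membered non-aromatic ring, with the heavy-atom count unchanged, does not move the result beyond the scatter in this assay (a 1.4-fold higher number from compound 3 to compound 4 (0.13 log units; within the scatter)). The earlier diethylcarbamoyl steps therefore carry over to (pyrrolidin-1-yl)carbonyl on the double-bonded ring carbon, which gives modest steps both in place of methoxymethyl (a 4.0-fold higher number from compound 1 to compound 4 (0.60 log units; beyond the scatter)) and in place of the silicon-bearing group of compound 2 (a 4.4-fold higher number from compound 2 to compound 4 (0.65 log units; beyond the scatter)). Nothing measured here accounts for these steps.

The compounds shown leave open whether other amines on this carbonyl carbon, such as dimethylamino, piperidin-1-yl or morpholin-4-yl, would also stay within the scatter. They also leave open how a carboxylic acid at the same place would compare.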